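Aryl swap on the acylguanidine side chain: furan to phenyl

The compounds below may be only part of what the source reports. "The series", "measured", "known", "first", "only" and "open" are said of these compounds alone.

Compounds measured so far:
compound 1 `CCCCCNC(=O)/N=C(\N)NCCCc1sc(N)nc1C`: 4.47 nM
compound 2 `Cc1nc(N)sc1CCCN/C(N)=N/C(=O)NCc1ccco1`: 10.5 nM
compound 3 `Cc1nc(N)sc1CCCN/C(N)=N/C(=O)NC(C)c1ccco1`: 31.6 nM

In an assay on membranes from Sf9 cells for displacement of a labelled ligand from histamine H2 receptor (Homo sapiens), read by scintillation counting, with a stated time of 60 min (a lower number here means a stronger inhibitor, a higher number a weaker inhibitor), compound 1 gives 4.47 nM. In this assay compound 2 gives 10.5 nM, and compound 3 gives 31.6 nM. Compound 3 stands at the highest number of the three: a 7.1-fold higher number from compound 1 to compound 3 (0.85 log units; beyond the scatter) and a 3.0-fold higher number from compound 2 to compound 3 (0.48 log units; beyond the scatter), both beyond the scatter, while a 2.3-fold higher number from compound 1 to compound 2 (0.37 log units; beyond the scatter).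

Compound 4 `Cc1nc(N)sc1CCCN/C(N)=N/C(=O)N[C@H](C)c1ccccc1` is not yet measured. It differs from compound 3 as follows: 1-phenylethyl in place of 1-(furan-2-yl)ethyl on an amide-type nitrogen. Among the measured compounds shown here, no measured step changes the aromatic ring itself; the measured steps all alter the chain on the amide-type nitrogen, and the steps to compound 3 were modest. The 1-phenylethyl group keeps the branch that, in compound 3, went with a 3.0-fold higher number from compound 2 to compound 3 (0.48 log units; beyond the scatter). The size of the change is therefore expected to be small, without clear direction.

For compound 4 in this assay the expected value is 25 nM, within 8 nM to 80 nM, that is an expected step of a 1.3-fold lower number from compound 3 to compound 4 (0.10 log units; within the scatter).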

Compound 4, inhibition constant: 17.8 nM
For compound 4 the middle estimate is 1.4-fold (0.15 log units) above the measured one, and the stated range covers the measured number.
By their numbers in this assay, from the lowest: compound 1; then compounds 2, 4 and 3 (each within the scatter of the next, the first and the last beyond it).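

In this assay, exchanging the aromatic ring on the branched side chain gives a step that stays within the scatter (a 1.8-fold lower number from compound 3 to compound 4 (0.25 log units; within the scatter)), even though a five-membered ring with one hydrogen-bond acceptor gives way to a six-membered ring of carbon only. The 1-phenylethyl group is also level with the unbranched (furan-2-yl)methyl group (a 1.7-fold higher number from compound 2 to compound 4 (0.23 log units; within the scatter)), while the gap to the pentyl group remains beyond the scatter (a 4.0-fold higher number from compound 1 to compound 4 (0.60 log units; beyond the scatter)). Nothing available explains any of these steps.

The step from compound 3 to compound 4 also brings in a defined stereocentre, so its contribution cannot be separated from that of the ring exchange. Also open, from the compounds shown here alone, is how an unbranched benzyl group or a pyridine ring would compare with the 1-phenylethyl group on this amide-type nitrogen.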